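Thiocarbonyl amine swap in the fluoropyridine amidrazone series

The source may report more compounds than this note shows. Statements on the series, on what has been measured and on what is new or still open speak of the compounds shown alone.

Compound 2 `N/C(=N\NC(=S)N1CCCC1)c1ccc(F)cn1`, compound 1 `N/C(=N\NC(=S)N1CCN(c2ccccn2)CC1)c1ccc(F)cn1` and compound 3 `Cc1ccnc(/C(N)=N/NC(=S)N2CCN(c3ccccn3)CC2)c1` share one core and differ at two places, the pyridine substituent and the amine on the thiocarbonyl carbon. In a functional assay on A-375 cells (Homo sapiens) for cytotoxicity, read by MTT assay, with a stated time of 72 h, tested at 3 uM (a higher number here means more inhibition of growth at the concentration tested, a lower number less inhibition of growth), compound 2 gives 81.8%, the highest of the three numbers. Compound 3 gives 74.8%, which lies within the scatter of compound 2. Compound 1 gives 53.1%, beyond the scatter from compound 2. For the measured compounds named here, the only single-place step among the measured compounds, a number 21.7 percentage points higher from compound 1 to compound 3 (beyond the scatter), concerns the pyridine part and not the thiocarbonyl amine.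

Compound 4 `N/C(=N\NC(=S)N1CCSCC1)c1ccc(F)cn1` differs from compound 2 at that amine: thiomorpholin-4-yl in place of pyrrolidin-1-yl on a thiocarbonyl carbon. Going by the values given here, no measured step bears on this change. Among the compounds with values here, compounds 1 and 2 also differ at the thiocarbonyl carbon, but in more than one feature, so their values show only that compound 1 stands below compound 2 in this assay. Within the data shown here, with no direct precedent, the expectation is a step of modest size downward, with a wide range. Compound 4 is estimated at 70%, between 50% and 88%, which corresponds to an expected step of a number 11.8 percentage points lower from compound 2 to compound 4 (beyond the scatter).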

Compound 4, percent growth inhibition at one concentration: 62.2%
Beside the measured number, compound 4's estimate is 7.8 percentage points above it, and the stated range covers the measured number.
By their numbers in this assay, from the lowest: compounds 1 and 4 (each within the scatter of the next); then compounds 3 and 2 (each within the scatter of the next).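

Thiomorpholin-4-yl in place of pyrrolidin-1-yl gives a number 19.6 percentage points lower from compound 2 to compound 4 (beyond the scatter) in this assay and provides the first single-place reading at the amine on the thiocarbonyl carbon, so growth inhibition at the concentration tested does respond to this change with the 5-fluoropyridin-2-yl group held constant. The two compounds carrying a six-membered ring at this place also sit close together: compound 1 gives 53.1% and compound 4 gives 62.2% as values within the scatter of each other, while the pyrrolidin-1-yl of compound 2 remains the only five-membered amine shown. No measurement shown accounts for the size of this step or ties it to any feature of either group.

The swap changes ring size and adds the ring sulfur at once, so the two cannot be told apart here; piperidin-1-yl, which keeps the six-membered ring without the sulfur, and morpholin-4-yl, with oxygen in place of that sulfur, would separate them. On these data alone, it also stays open whether the same amine change gives a similar step with the 4-methylpyridin-2-yl group of compound 3 in place of 5-fluoropyridin-2-yl.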